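This account rests on a few compounds, and the source may have more. Where it says the series, first, only, none or still open, it means among the compounds named here.

Of the compounds shown here, three with a shared core have been tested in a functional assay on NCI-H460 cells (Homo sapiens) for antiproliferative activity, read by CCK-8 assay, with a stated time of 72 h, tested at 8 uM; on this read-out higher numbers stand for a stronger effect at the one concentration tested and lower numbers for a weaker effect. Compound 1 `COC(CCn1cnc2c(NCc3ccc(C(=O)Nc4ccccc4N)cc3)nc(Cl)nc21)OC` gives 51.2%, compound 2 `Nc1ccccc1NC(=O)c1ccc(Cn2cnc3c(Nc4ccccc4)nc(Cl)nc32)cc1` gives 77.8%, and compound 3 `CCCCn1cnc2c(Nc3ccccc3)nc(NCOCc3ccc(/C=C/C(=O)Nc4ccccc4N)cc3)nc21` gives 34.2%. Among these three numbers compound 2 stands highest: its nearest neighbour is compound 1, whose number lies lower by a margin beyond the scatter, and furthest away lies compound 3, lower again by a margin beyond the scatter.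

Compound 4 `Nc1ccccc1NC(=O)c1ccc(Cn2cnc3c(Nc4cccc(Cl)c4)nc(Cl)nc32)cc1` has not yet been measured in this assay. It differs from compound 2 in one place: chloro in place of hydrogen on an aromatic carbon. For the measured compounds named here, no pair of measured compounds that differ in only one place is available, so there is nothing measured to show what a single chloro in place of hydrogen does here. Compound 2 already gives 77.8%, the top of the measured numbers, which leaves limited room upward. The step expected here is a number 0.2 percentage points higher from compound 2 to compound 4 (within the scatter), small enough that it may well lie within the scatter. For compound 4 the estimated value in this assay is 78%, with a range from 60% to 92%.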

Compound 4, a percentage reported as inhibition, at one concentration (the size of the read-out at that concentration, not a potency): 67%
Compound 4: middle estimate off by 11 percentage points, on the high side, within the range that was stated.
By their numbers in this assay, from the lowest: compound 3; then compound 1; then compound 4; then compound 2.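

In this assay, the change from phenyl to 3-chlorophenyl gives the first measured effect of altering just one place in this series: a number 10.8 percentage points lower from compound 2 to compound 4 (beyond the scatter). The step is modest, but it shows that this aromatic carbon is not a neutral spot, since adding a single chlorine atom, with no new ring and no hydrogen-bond donor or acceptor, is enough to move the read-out beyond the scatter. No measurement shown here explains why the number falls, so the result records the change without giving its cause.

This single pair cannot show whether the fall is specific to chloro or would also appear with another group at the same place, such as fluoro, methyl, methoxy or an amine. It also leaves open how chloro would behave on a different carbon of this ring, and, since the read-out comes from one concentration, whether compound 2 and compound 4 differ in the same way at other concentrations.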